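The source may hold more compounds than are shown below. What is called first, only, known or untested is meant among the compounds shown, and "the series" means these compounds.

Of the compounds shown here, three of one shared core have been measured in an assay on isolated protein for inhibition of NUAK family SNF1-like kinase 2 (Homo sapiens), read by ADP-Glo, with a stated time of 60 min, tested at 10 uM, in the presence of a further agent that is not named here; on this read-out lower numbers stand for less inhibition and higher numbers for more inhibition at the one concentration tested (going by the name of the read-out). Compound 1 `CCCN(CCC)c1ccc(Nc2ncc(Cl)c(Oc3cccc(NC(=O)CC)c3)n2)cc1` gives "not active" (no number reported) in this assay, so no number stands for it. Compound 2 `CCC(=O)Nc1cccc(Oc2nc(Nc3ccc(N4CCN(C)CC4)cc3)ncc2Cl)c1` gives 82.6%, and compound 3 `CCC(=O)Nc1cccc(Oc2nc(Nc3ccc(N4CCCCC4)cc3)ncc2Cl)c1` gives 72.3%. Compound 3 therefore holds the lower of the two numbers shown, with compound 2 its nearest neighbour; the one measured step, a number 10.3 percentage points lower from compound 2 to compound 3 (beyond the scatter), lies beyond the scatter and is modest in size.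

Compound 4 `CCC(=O)Nc1cccc(Oc2nc(Nc3ccc(N(CC)CC)cc3)ncc2Cl)c1` differs from compound 3 in one place: diethylamino in place of piperidin-1-yl on an aromatic carbon. Within the data shown here, no measured step covers this exact exchange. Among the measured compounds shown here, the only step at hand, a number 10.3 percentage points lower from compound 2 to compound 3 (beyond the scatter), swaps one ring amine for another, and compound 1, which carries an open-chain dipropylamino group, reports "not active" (no number reported). Taken together these suggest that moving from the ring amine of compound 3 to an open-chain amine is more likely to lower than to raise the read-out, though the size is uncertain.

The estimate for compound 4 is 55%, with a range from 20% to 78%. That estimate corresponds to an expected step of a number 17.3 percentage points lower from compound 3 to compound 4 (beyond the scatter), a drop beyond the scatter.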

Compound 4, a percentage reported as inhibition, at one concentration (the size of the read-out at that concentration, not a potency): 21.2%
Estimate against measurement, compound 4: 33.8 percentage points above; low and high end bracket the measured number.
By their numbers in this assay, from the lowest: compound 4; then compound 3; then compound 2.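

In this assay, replacing piperidin-1-yl with diethylamino opens the ring and leaves the counts of hydrogen-bond donors and acceptors and the net charge unchanged, yet it produces a large step, a number 51.1 percentage points lower from compound 3 to compound 4 (beyond the scatter), whereas exchanging one ring amine for another gave only a number 10.3 percentage points lower from compound 2 to compound 3 (beyond the scatter). The comparison with the methylated ring amine is larger still, a number 61.4 percentage points lower from compound 2 to compound 4 (beyond the scatter), and compound 1, with an open-chain dipropylamino group, gives "not active" (no number reported) in the same assay, so among these four compounds the two ring amines carry the higher numbers and neither open-chain amine matches them. Nothing available explains why this position is so sensitive to this change.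

The compounds shown leave open whether the six-membered ring itself matters or whether a smaller ring, such as pyrrolidin-1-yl, or a shorter open-chain group, such as dimethylamino, would also hold the read-out up. They also leave open whether a ring with a different second ring atom, such as morpholin-4-yl, would behave like compound 2 or compound 3, and how these single-concentration numbers would translate into potency.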